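The source may hold more compounds than are shown below. What is called first, only, known or untested is meant among the compounds shown, and "the series" means these compounds.

Of the compounds shown here, three sharing one core have been measured in a functional assay (aorta) with Rattus norvegicus as the target; a lower number here means a less potent compound, a higher number a more potent compound, by a factor of ten per unit of this negative logarithm. Compound 1 `CC1(C)C=C(n2ccccc2=O)c2cc(C(=N)NO)ccc2O1` gives 5.99 and stands highest of the three. Compound 3 `CC1(C)C=C(n2ccccc2=O)c2cc(OC(=O)Nc3ccc(C(F)(F)F)cc3)ccc2O1` gives 5.1, and compound 2 `CC1(C)C=C(n2ccccc2=O)c2cc(OCC(=O)c3ccc(F)cc3)ccc2O1` gives 4.63; both of these gaps to compound 1 lie beyond the usual scatter, so compound 1 is the most potent of the measured set.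

Compound 4 `CC1(C)C=C(n2ccccc2=O)c2cc(C(F)(F)F)ccc2O1` is the unmeasured one. It differs from compound 1 in this way: a group of 4 heavy atoms (1 carbon, 3 fluorine; no ring) in place of a group of 4 heavy atoms (1 carbon, 2 nitrogen, 1 oxygen; no ring), on an aromatic carbon. The group that leaves carries hydrogen-bond donors and acceptors; the trifluoromethyl that enters carries none.

For the measured compounds named here, no step between two measured compounds that differ in one place is available, so there is no matched pair to lean on. What the numbers do show is that compound 1, which carries the donor-bearing group, gives 5.99, while the two compounds without it gave lower values. On that basis a downward step is expected, from compound 1 to compound 4 of about a number 0.69 log units lower from compound 1 to compound 4 (beyond the scatter). The value expected for compound 4 is 5.3, with a range from 4.6 to 6.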

Compound 4, logarithm of the reciprocal of the active concentration, log(1/C): 7.61
Beside the measured number, compound 4's estimate is 2.31 log units below it, outside the stated range (above it).
By their numbers in this assay, from the lowest: compound 2; then compound 3; then compound 1; then compound 4.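

Placing trifluoromethyl on this aromatic carbon, in place of the group with hydrogen-bond donors and acceptors, gives a number 1.62 log units higher from compound 1 to compound 4 (beyond the scatter) in this assay. This shows that hydrogen-bond donors and acceptors at this position are not needed for high potency in this pair, since the entering group has none. The two groups also have the same number of heavy atoms, so the step comes from a change in their identity rather than in that count, but nothing measured here explains why it is so large.

From the compounds shown here alone, it remains open whether this gain is particular to trifluoromethyl or would also appear with another small group, such as a nitrile or a methyl. Going by these compounds, how an amine or a carboxylic acid on this same carbon would compare also remains unknown.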